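Swapping the amide aryl group: cytotoxicity on PC-3 cells

The source may report more compounds than this note shows. Statements on the series, on what has been measured and on what is new or still open speak of the compounds shown alone.

Compound 1, `CCc1cccc(NC(=O)C2CCCN(C(=O)c3cc(C(F)(F)F)cc(C(F)(F)F)c3)C2)c1`: 0%
Compound 2, `O=C(Nc1cccc(-c2cnco2)c1)C1CCCN(C(=O)c2cc(C(F)(F)F)cc(C(F)(F)F)c2)C1`: 9%

The two measured compounds share one core and differ only in the group attached to the amide nitrogen. In an ADME assay on PC-3 cells (Homo sapiens) for cytotoxicity, read by WST assay, tested at 100 uM (on this read-out higher numbers stand for more inhibition at the one concentration tested (going by the name of the read-out) and lower numbers for less inhibition), compound 1 gives 0%, and compound 2 gives 9%. The step of a number 9 percentage points higher from compound 1 to compound 2 (within the scatter) lies within the scatter, so the two compounds cannot be told apart on this read-out. Compound 2 has the highest of the two numbers, but its nearest neighbour, compound 1, is within the scatter of it.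

Compound 3, `O=C(Nc1ccc(Cl)nc1)C1CCCN(C(=O)c2cc(C(F)(F)F)cc(C(F)(F)F)c2)C1`, differs from compound 2 in one place: 6-chloropyridin-3-yl in place of 3-(1,3-oxazol-5-yl)phenyl on an amide-type nitrogen. Within the data shown here, no measured step swaps these exact groups. Among the measured compounds shown here, the only step recorded, from compound 1 to compound 2, changed the group on an aromatic carbon and moved the number only within the scatter, and both measured compounds sit near the bottom of the scale. The expected step of a number 3 percentage points lower from compound 2 to compound 3 (within the scatter) is therefore none beyond the scatter. Compound 3 is estimated to give 6%, within a range from -10% to 25%.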

Compound 3, a percentage reported as inhibition, at one concentration (the size of the read-out at that concentration, not a potency): 25%
Compound 3: the middle estimate sits 19 percentage points below what was measured; measured number inside the range.
By their numbers in this assay, from the lowest: compounds 1 and 2 (each within the scatter of the next); then compound 3.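

On the amide-type nitrogen, the choice of group can shift the number by more than the scatter. In this assay, 6-chloropyridin-3-yl gives a number 16 percentage points higher from compound 2 to compound 3 (beyond the scatter) when it replaces 3-(1,3-oxazol-5-yl)phenyl, and a number 25 percentage points higher from compound 1 to compound 3 (beyond the scatter) when it replaces 3-ethylphenyl, so the first pair's lack of a clear difference does not hold for every group at this place. Nothing measured alongside these compounds accounts for the rise.

Each of these swaps changes the ring, its hetero atom and the chlorine all at once, so the compounds shown cannot tell whether the chlorine, the ring nitrogen or the pair of them goes with the higher number. A plain pyridin-3-yl group without chlorine and a chlorophenyl group with carbon in place of the ring nitrogen would separate those parts, and a pyridine ring carrying an amine or a carboxylic acid where the chlorine sits would show whether the chlorine can be replaced at all.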